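Taking the Pentyl off the Selenium of Compound 2

The source may hold more compounds than are shown below. What is called first, only, known or untested is meant among the compounds shown, and "the series" means these compounds.

Compound 1 `Sc1nc(NCc2ccccc2)c2ccccc2n1`: 82400 nM
Compound 2 `CCCCC[Se]c1nc(NCc2ccccc2)c2ccccc2n1`: 34500 nM

In a functional assay on CCRF-CEM cells (Homo sapiens) for cytotoxicity, read by MTT assay, with a stated time of 72 h (a lower number here means a stronger inhibitor of growth, a higher number a weaker inhibitor of growth), compound 1 gives 82400 nM and compound 2 gives 34500 nM. Within the data shown here, compound 2 stands lowest of the two numbers, the only step being a 2.4-fold lower number from compound 1 to compound 2 (0.38 log units; beyond the scatter). Compound 3 `[SeH]c1nc(NCc2ccccc2)c2ccccc2n1` differs from compound 2 by hydrogen in place of pentyl on a selenium. That single measured step bears on it only loosely, since a 2.4-fold lower number from compound 1 to compound 2 (0.38 log units; beyond the scatter) also swapped sulfur for selenium. A modest move back toward compound 1 is expected, so compound 3 is estimated at 70000 nM (range 25000 nM to 200000 nM). This would mean an expected 2.0-fold higher number from compound 2 to compound 3 (0.31 log units; beyond the scatter).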

Compound 3, concentration for 50% growth inhibition: > 100000 nM
Compound 3: a limit, no number; the forecaster's own chance of this, stated with the estimate: 15%; middle value at least 1.4-fold (0.15 log units) away from the limit.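

Compound 3 gives only a limit, not a number: the limit of > 100000 nM in this assay, at which 1 of the 3 values shown sits. Hydrogen in place of pentyl on the selenium gives an at least 2.8-fold higher number from compound 2 to compound 3 (0.46 log units; beyond the scatter), so among these compounds the lower number depends on the pentyl being present, which the earlier step, with its two changes, could not separate. Selenium in place of sulfur alone gives an at least 1.2-fold higher number from compound 1 to compound 3 (0.08 log units; that floor lies within the scatter), which fixes no order between the two.

The compounds shown leave open how a methyl group or a longer chain on the selenium would read, and whether pentyl on sulfur would match compound 2.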